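From 2-bromophenyl to 4-(dimethylamino)phenyl

The source may hold more compounds than are shown below. What is called first, only, known or untested is meant among the compounds shown, and "the series" means these compounds.

Compound 1 `C[C@H]1CC[C@@H]2[C@@H](OC(=O)[C@]23CC(c2c(Cl)cccc2Cl)=NO3)[C@]2(C)C(=O)C=C[C@@]12O`: 2.67
Compound 2 `C[C@H]1CC[C@@H]2[C@@H](OC(=O)[C@]23CC(c2ccc(Cl)cc2)=NO3)[C@]2(C)C(=O)C=C[C@@]12O`: 2.09
Compound 3 `C[C@H]1CC[C@@H]2[C@@H](OC(=O)[C@]23CC(c2ccccc2Br)=NO3)[C@]2(C)C(=O)C=C[C@@]12O`: 2.22

In a physicochemical assay for lipophilicity (a lower number here means a more polar compound, a higher number a more lipophilic compound), compound 3 at 2.22 cannot be told apart from compound 2, the step being a number 0.13 log units higher from compound 2 to compound 3 (within the scatter). Compound 1 stands clear of both, with a number 0.58 log units lower from compound 1 to compound 2 (beyond the scatter) and a number 0.45 log units lower from compound 1 to compound 3 (beyond the scatter).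

The unmeasured compound 4 `C[C@H]1CC[C@@H]2[C@@H](OC(=O)[C@]23CC(c2ccc(N(C)C)cc2)=NO3)[C@]2(C)C(=O)C=C[C@@]12O` keeps the shared core and differs from compound 3 in one group: 4-(dimethylamino)phenyl in place of 2-bromophenyl on a carbon with a double bond to nitrogen.

For the measured compounds named here, no measured step brings in the 4-(dimethylamino)phenyl group, so the evidence is indirect. The two larger steps both start from the 2,6-dichlorophenyl group, which neither compound 3 nor compound 4 carries, and they bear on this change only loosely. The closest guide is the exchange between 4-chlorophenyl and 2-bromophenyl, which stayed within the scatter. Among the groups measured without a second chlorine, the numbers have so far stayed close together.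

A small step is therefore expected in this assay, leaning downward and possibly not beyond the scatter. The expected size is a number 0.22 log units lower from compound 3 to compound 4 (within the scatter). Compound 4 is estimated at 2, with an expected range of 1.6 to 2.4.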

Compound 4, partition coefficient: 1.51
Compound 4: the middle estimate sits 0.49 log units above what was measured, and the stated range ends above it.
By their numbers in this assay, from the lowest: compound 4; then compounds 2 and 3 (each within the scatter of the next); then compound 1.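

In this assay, the earlier exchange between the two groups without a second chlorine left the impression of a flat position, but the 4-(dimethylamino)phenyl group breaks that picture with a number 0.71 log units lower from compound 3 to compound 4 (beyond the scatter). The sharpest reading comes from the exchange of a single substituent on the aromatic ring, dimethylamino in place of chloro, which gives a number 0.58 log units lower from compound 2 to compound 4 (beyond the scatter) and shows that the choice of this one group can move the number beyond the scatter, while the aromatic ring itself stays the same. The span at this position on the shared core is also wider than before, reaching a number 1.16 log units lower from compound 1 to compound 4 (beyond the scatter) and placing compound 4 lowest of the four, though nothing available here ties this drop to any measured property of the group.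

The compounds shown leave open whether the step belongs to the dimethylamino group in particular or would also come with a primary amine, a morpholine ring or a methoxy group in its place. They also leave open how a carboxylic acid on the aromatic ring would compare with compound 4 in this assay.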